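The source may report more compounds than this note shows. Statements on the series, on what has been measured and on what is new or still open speak of the compounds shown alone.

In a functional assay on SMMC-7721 cells (Homo sapiens) for cytotoxicity, read by MTT assay, with a stated time of 24 h (a higher number here means a weaker inhibitor, a lower number a stronger inhibitor), compound 2 `CN1C/C(=C\c2ccncc2)C(=O)/C(=C/c2ccccc2F)C1` gives 7000 nM and sits within the usual scatter of its two measured neighbours. Compound 1 `CN1C/C(=C\c2cccnc2)C(=O)/C(=C/c2ccccc2F)C1` reads 5420 nM and compound 3 `CN1C/C(=C\c2ccncc2)C(=O)/C(=C/c2ccccc2C(F)(F)F)C1` reads 4100 nM in this assay as well. Compound 4 `CN1C/C(=C\c2ccncc2)C(=O)/C(=C/c2ccc(C#N)cc2)C1` is not yet measured, and 4-cyanophenyl in place of 2-fluorophenyl on a double-bonded chain carbon bound to a double-bonded ring carbon describes how it departs from compound 2. Going by the values given here, two measured steps bear on this, a 1.7-fold lower number from compound 2 to compound 3 (0.23 log units; within the scatter) for trifluoromethyl in place of fluoro on an aromatic carbon and a 1.3-fold higher number from compound 1 to compound 2 (0.11 log units; within the scatter) for pyridin-4-yl in place of pyridin-3-yl, and both stay within the scatter. Among the compounds with values here, no measured compound carries 4-cyanophenyl, so the direction remains uncertain. The expected change is small, with a 1.4-fold lower number from compound 2 to compound 4 (0.15 log units; within the scatter) estimated in this assay and nothing expected beyond the scatter. For compound 4 the estimate is 5000 nM with an expected range from 2500 nM to 10000 nM overall.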

Compound 4, half-maximal inhibitory concentration: 18500 nM
Beside the measured number, compound 4's estimate is 3.7-fold (0.57 log units) below it, and the stated range ends below it.
By their numbers in this assay, from the lowest: compounds 3, 1 and 2 (each within the scatter of the next); then compound 4.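

In this assay, the group on a double-bonded chain carbon bound to a double-bonded ring carbon can shift the result: 4-cyanophenyl in place of 2-fluorophenyl gives a 2.6-fold higher number from compound 2 to compound 4 (0.42 log units; beyond the scatter). The step is modest, but unlike the two earlier steps it lies beyond the scatter, and it goes toward a weaker inhibitor. The data offer no explanation for this shift.

This single swap changes both the substituent and its numbered ring position, and the compounds shown do not separate the two. Open questions include how 4-fluorophenyl or 2-cyanophenyl would read at this place.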